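Cytotoxicity notes on the series: compound 3 to compound 4

This account rests on a few compounds, and the source may have more. Where it says the series, first, only, none or still open, it means among the compounds named here.

Among the compounds with values here, the series so far holds compound 1 `CC(C)=CCc1cc(C(=O)/C=C/c2ccc(O)cc2)c(O)cc1O`, compound 2 `CC(C)=CCc1cc2c(cc1O)O[C@H](c1ccc(O)cc1)CC2=O` and compound 3 `C=C[C@@](C)(/C=C/c1ccc(O)cc1)CC[C@@H](O)C(C)(C)O`, each tested in a functional assay on A549 cells (Homo sapiens) for cytotoxicity, read by MTT assay, with a stated time of 48 h; a lower number here means a stronger inhibitor, a higher number a weaker inhibitor. In this assay compound 1 gives only a limit, > 10000 nM. Compound 2 likewise reaches only the limit, > 10000 nM. Compound 3 also gives a limit rather than a number, > 10000 nM. Where compound 3 stands can therefore be said only with reference to the limit of > 10000 nM in this assay, at which 3 of the 3 values shown sit; no ordering among the three compounds is possible from these values, and none is the strongest or weakest.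

Compound 4 `C=C[C@@](C)(/C=C/c1ccc(O)cc1)C/C=C/C(C)(C)O` is not yet measured. It differs from compound 3 by 3-hydroxy-3-methylbut-1-en-1-yl in place of 2,3-dihydroxy-3-methylbutyl on a saturated chain carbon, two bonds along the chain from two double-bonded chain carbons. Within the data shown here, no step between measured compounds exists in this set, so the numbers give no indication of how such a change shifts potency. With all three values sitting at the limit, there is no ground to expect compound 4 to move into the measurable range. The estimate for compound 4 is 20000 nM, between 8000 nM and 60000 nM. The implied step that the limit leaves unreadable from compound 3 to compound 4 is expected to be none beyond the scatter, most likely another limit.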

Compound 4, half-maximal inhibitory concentration: > 10000 nM
Compound 4 ended at the assay's limit; the forecaster's own chance of this, stated with the estimate: 80%; the middle value lies beyond the limit too.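

No step can be read between compound 3 and compound 4, as both values are limits: the limit of > 10000 nM in this assay, at which 4 of the 4 values shown sit.

The compounds shown leave open whether 3-hydroxy-3-methylbut-1-en-1-yl in place of 2,3-dihydroxy-3-methylbutyl alters potency at all, and what would bring this series into the measurable range in this assay of the read-out.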